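The compounds below may be only part of what the source reports. "The series", "measured", "known", "first", "only" and "open" are said of these compounds alone.

Measured compounds in an assay on CHO cells for antagonist activity at transient receptor potential cation channel subfamily V member 1 (Homo sapiens), read by scintillation counting, with a stated time of 5 min; a lower number here means a stronger inhibitor, a higher number a weaker inhibitor:
- compound 1 `CC(C(=O)NCc1ccc(C(F)(F)F)nc1N(C)S(=O)(=O)c1ccccc1)c1ccc(NS(C)(=O)=O)c(F)c1`, 100 nM
- compound 2 `CC(C(=O)NCc1ccc(C(F)(F)F)nc1N(C(C)C)S(=O)(=O)c1ccccc1)c1ccc(NS(C)(=O)=O)c(F)c1`, 27.6 nM
- compound 3 `CC(C(=O)NCc1ccc(C(F)(F)F)nc1N(CC1CCCCC1)S(=O)(=O)c1ccccc1)c1ccc(NS(C)(=O)=O)c(F)c1`, 10 nM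

Compound 1 stands at the highest number of the three, the weakest inhibitor of the set. The nearest is compound 2, with a 3.6-fold lower number from compound 1 to compound 2 (0.56 log units; beyond the scatter); the furthest is compound 3, with a 10-fold lower number from compound 1 to compound 3 (1.00 log units; beyond the scatter). Between the two, a 2.8-fold lower number from compound 2 to compound 3 (0.44 log units; beyond the scatter).

Compound 4 `CC(C(=O)NCc1ccc(C(F)(F)F)nc1N(Cc1ccccc1)S(C)(=O)=O)c1ccc(NS(C)(=O)=O)c(F)c1` is not yet measured. Against compound 1 the change is benzyl(methylsulfonyl)amino in place of methyl(phenylsulfonyl)amino on an aromatic carbon. The measured steps bear on it only in part. All three steps enlarged the substituent on the sulfonamide nitrogen and each lowered the number, the largest being a 10-fold lower number from compound 1 to compound 3 (1.00 log units; beyond the scatter). Compound 4 also carries a larger group on that nitrogen, a benzyl, which points the same way. Within the data shown here, at the same time the sulfonyl side changes from phenyl to methyl, and no measured pair tests that change on its own, so the size of the step is less certain than the direction.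

On balance a modest lowering is expected, a 2.5-fold lower number from compound 1 to compound 4 (0.40 log units; beyond the scatter), with a wide range. The estimate for compound 4 in this assay is 40 nM, between 10 nM and 160 nM.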

Compound 4, inhibition constant: 25 nM
The estimate for compound 4 lay 1.6-fold (0.20 log units) above the measured number; measured number inside the range.
By their numbers in this assay, from the lowest: compound 3; then compounds 4 and 2 (each within the scatter of the next); then compound 1.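

Moving the ring from the sulfonyl side to the nitrogen side, with benzyl(methylsulfonyl)amino in place of methyl(phenylsulfonyl)amino on the aromatic carbon, gives a 4.0-fold lower number from compound 1 to compound 4 (0.60 log units; beyond the scatter). Among these compounds, this is the first sign at this position that the phenylsulfonyl part of compound 1 is not needed to reach a lower number in this assay: a methylsulfonyl group is tolerated when the nitrogen carries benzyl, and the lowering seen earlier with larger nitrogen substituents also appears here, on a different sulfonyl group, while the counted hydrogen-bond donors and acceptors of the group stay the same. Nothing available explains the step, and the data give no reason for it.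

The step bundles two changes, so its share between the benzyl and the methylsulfonyl stays unresolved; a compound pairing benzyl with phenylsulfonyl, or methyl with methylsulfonyl, would separate them. The compounds shown also leave open how the number responds to a longer chain on the sulfonamide nitrogen, or to an amine or a carboxylic acid at this aromatic carbon in place of the whole sulfonamide.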